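Solubility notes on an aminothienopyrimidine series

The source may hold more compounds than are shown below. What is called first, only, known or untested is meant among the compounds shown, and "the series" means these compounds.

Three measured compounds share one core and are compared in a physicochemical assay for solubility, at pH 2; on this read-out higher numbers stand for higher solubility and lower numbers for lower solubility. Compound 1 `CN(C)CCCNc1nc(N)nc2cc(-c3ccc(C(F)(F)F)cc3)sc12` gives 210 ug/mL in this assay. Compound 2 `CN(C)CCCNc1nc(NCc2ccccc2)nc2cc(-c3ccc(C(F)(F)F)cc3)sc12` gives 208 ug/mL, and compound 3 `CN(C)CCCNc1nc(N2CCNCC2)nc2cc(-c3ccc(C(F)(F)F)cc3)sc12` gives 198 ug/mL. On these numbers compound 1 stands highest of the three, but every gap is within the scatter: a 1.0-fold lower number from compound 1 to compound 2 (0.00 log units; within the scatter), a 1.1-fold lower number from compound 1 to compound 3 (0.03 log units; within the scatter) and a 1.1-fold lower number from compound 2 to compound 3 (0.02 log units; within the scatter). All three measured steps touch only the amino group of compound 1 and leave the (3-(dimethylamino)propyl)amino side chain untouched.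

Compound 4 `Nc1nc(N2CCC(N)CC2)c2sc(-c3ccc(C(F)(F)F)cc3)cc2n1` differs from compound 1 at that side chain instead: 4-aminopiperidin-1-yl in place of (3-(dimethylamino)propyl)amino on an aromatic carbon. Within the data shown here, no measured step changes this position, so none bears on it directly. Among the measured compounds shown here, what the measured steps do show is that this assay has been flat across the series so far; none of them moved beyond the scatter. With the leaving and entering groups matched in heavy atoms, donors and acceptors, no step beyond the scatter is expected in this assay from compound 1 to compound 4, that is a 1.1-fold lower number from compound 1 to compound 4 (0.02 log units; within the scatter). Compound 4 is therefore estimated at 200 ug/mL, with a range from 100 ug/mL to 400 ug/mL.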

Compound 4, solubility: 134 ug/mL
Estimate against measurement, compound 4: 1.5-fold (0.17 log units) above; measured number inside the range.
By their numbers in this assay, from the lowest: compounds 4, 3, 2 and 1 (each within the scatter of the next).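

Among these compounds, compound 4 gives the first reading at the side-chain position, where all earlier steps changed only the amino group: 4-aminopiperidin-1-yl, with its six-membered non-aromatic ring, stands in place of the open-chain (3-(dimethylamino)propyl)amino, and the result in this assay is a 1.6-fold lower number from compound 1 to compound 4 (0.20 log units; within the scatter). Across this one change, the heavy-atom, donor and acceptor counts stay the same while the chain becomes a ring, and the read-out does not separate the two groups, so the flat picture seen at the amino group also holds at this second position. The data in hand give no account of what lies behind this reading.

Still open, from the compounds shown here alone, is whether a side chain carrying no amine nitrogen, such as morpholin-4-yl or a short alkoxy chain, or one ending in a carboxylic acid, would also stay within the scatter at this position in this assay. Also open, going by these compounds, is how the read-out responds at the trifluoromethyl group, which is common to all four compounds, if a nitrile or a carboxylic acid stands in its place.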